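Amide to urea on a shared pyrazole-bearing core

The source may report more compounds than this note shows. Statements on the series, on what has been measured and on what is new or still open speak of the compounds shown alone.

Compound 1 `O=C(Nc1cccc(-n2cc(-c3ccncc3)c(-c3ccc(Cl)c(O)c3)n2)c1)Nc1ccc(Cl)c(Cl)c1`: > 32500 nM
Compound 2 `COc1cc(-c2nn(-c3cccc(NC(=O)c4ccc(Cl)c(C(F)(F)F)c4)c3)cc2-c2ccncc2)ccc1Cl`: > 32500 nM
Compound 3 `O=C(Nc1cccc(-n2cc(-c3ccncc3)c(-c3ccc(Cl)c(O)c3)n2)c1)Nc1cc(C(F)(F)F)cc(C(F)(F)F)c1`: 2800 nM

In a functional assay on U-251 cells (Homo sapiens) for inhibition, read by sulforhodamine B assay, with a stated time of 48 h (on this read-out higher numbers stand for lower toxicity in this test and lower numbers for higher toxicity in this test), compound 1 gives > 32500 nM, which is a limit of the assay and not a number. Compound 2 gives > 32500 nM, again only a limit. Among the compounds with values here, compound 3 gives 2800 nM, the only number among the three. Within the data shown here, compound 2 therefore sits together with compound 1 at the limit of > 32500 nM in this assay, at which 2 of the 3 values shown sit, and there is no measured step from it to any other compound.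

Compound 4 `COc1cc(-c2nn(-c3cccc(NC(=O)Nc4cccc(C(F)(F)F)c4)c3)cc2-c2ccncc2)ccc1Cl` differs from compound 2 in one place: (3-(trifluoromethyl)phenyl)amino in place of 4-chloro-3-(trifluoromethyl)phenyl on a carbonyl carbon. Compound 4 thus carries a urea like compound 1 and compound 3, but with a single trifluoromethyl on the outer ring. Compound 3 shows that a urea with two trifluoromethyl groups reaches 2800 nM. Compound 1 with dichlorophenyl, by contrast, gives > 32500 nM, which is a limit of the assay. Compound 4 is expected to give 15000 nM, within 3000 nM to 32500 nM. That estimate means an expected step of an at least 2.1-fold lower number from compound 2 to compound 4 (0.33 log units; beyond the scatter) toward higher toxicity in this test, though a limit again remains quite possible.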

Compound 4, concentration lethal to 50% of the cells: 2920 nM
Compound 4: middle estimate off by 5.1-fold (0.71 log units), on the high side; measured number below the stated range.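

In this assay, putting (3-(trifluoromethyl)phenyl)amino in place of 4-chloro-3-(trifluoromethyl)phenyl on a carbonyl carbon gives an at least 11-fold lower number from compound 2 to compound 4 (1.04 log units; beyond the scatter), a large move toward higher toxicity in this test and the first step measured at this position. Compound 2 gives > 32500 nM, which is a limit of the assay and not a number. The full size of the step stays unknown, as it starts from that limit: the limit of > 32500 nM in this assay, at which 2 of the 4 values shown sit.

The compounds shown do not separate the entering amino nitrogen from the loss of the chlorine, so it remains open which of the two carries the step. From the compounds shown here alone, it also remains open how this assay would read with a morpholine, a carboxylic acid or a longer alkyl chain in place of the trifluoromethyl.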